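The source may hold more compounds than are shown below. What is called first, only, known or untested is meant among the compounds shown, and "the series" means these compounds.

Working notes on the series, read in an assay on cells for displacement of a labelled ligand from adenosine receptor A1 (Homo sapiens), read by scintillation counting and radioligand binding, with a stated time of 60 min, tested at 10 uM; on this read-out higher numbers stand for more inhibition at the one concentration tested (going by the name of the read-out) and lower numbers for less inhibition.

Measured so far:
- compound 1 `Clc1ccc(-c2nc(N3CCCCC3)c3nc[nH]c3n2)cc1` gives > 80%, a limit of the assay rather than a number.
- compound 2 `Oc1cccc(-c2nc(N3CCCCC3)c3nc[nH]c3n2)c1` gives > 80%, again a limit.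
- compound 3 `CN1CCN(c2nc(-c3cccc(O)c3)nc3[nH]cnc23)CC1` gives > 80%, also a limit.

All three values sit at the same limit, (the limit of > 80% in this assay, at which 3 of the 3 values shown sit). For that reason the step that the two limits leave unreadable from compound 2 to compound 1, made by the change (4-chlorophenyl in place of 3-hydroxyphenyl on an aromatic carbon), cannot be sized, and the same holds for the step that the two limits leave unreadable from compound 2 to compound 3, made by the change (4-methylpiperazin-1-yl in place of piperidin-1-yl on an aromatic carbon).

Not yet measured is compound 4 `CN1CCN(c2nc(-c3ccc(Cl)cc3)nc3[nH]cnc23)CC1`. It arises from compound 3 by the change (4-chlorophenyl in place of 3-hydroxyphenyl on an aromatic carbon), the same kind of change as from compound 2 to compound 1; the two cores differ as given in 4-methylpiperazin-1-yl in place of piperidin-1-yl on an aromatic carbon, so the place is meta to a 4-methylpiperazin-1-yl group here rather than meta to a piperidin-1-yl group there. Beside the unreadable step that the two limits leave unreadable from compound 2 to compound 1, the step that the limit leaves unreadable from compound 3 to compound 4 is expected to be small, resting on all three measured compounds reaching the limit (the limit of > 80% in this assay, at which 3 of the 3 values shown sit). Compound 4 is therefore expected to give 88%, most likely reported again as a limit.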

Compound 4, a percentage reported as inhibition, at one concentration (the size of the read-out at that concentration, not a potency): > 80%
Compound 4: only a limit was reported; the forecaster's own chance of this, stated with the estimate: 80%; the middle value lies beyond the limit too.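

Compound 4 gives > 80%, a limit of the assay and not a number. No new step can be read from compound 3 to compound 4 or from compound 1 to compound 4, because all four values sit at the same limit: the limit of > 80% in this assay, at which 4 of the 4 values shown sit.

The compounds shown leave open whether the four differ at all on this read-out, and by how much.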